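The source may report more compounds than this note shows. Statements on the series, on what has been measured and on what is new or still open speak of the compounds shown alone.

Working notes on the urea series. Among the measured compounds shown here, compound 1 `COc1ccc(NC(=O)Nc2cc(C)nc3ccccc23)cc1OC` was tested in an ADME assay for permeability, using PAMPA, at pH 7.4 (a higher number here means that the compound crosses the layer faster, a lower number that the compound crosses the layer more slowly), and gives 552 10^-6 cm/s, the lowest of the two numbers measured so far; its nearest neighbour is compound 2 `COc1cccc(NC(=O)Nc2cc(C)nc3ccccc23)c1`, which in this assay gives 818 10^-6 cm/s. For the measured compounds named here, the only step measured within the pair, a 1.5-fold higher number from compound 1 to compound 2 (0.17 log units; within the scatter), removes one methoxy from the shared core of compound 1 and leaves the number within the scatter.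

Compound 3 `COc1ccc(NC(=O)Nc2cc(C)nc3ccccc23)cc1` has not yet been measured in this assay. Its difference from compound 1 is hydrogen in place of methoxy on an aromatic carbon, that is, again the loss of one methoxy from the same aromatic ring as in the measured step, though it is the other methoxy that leaves. Going by the values given here, the one step that bears on it, a 1.5-fold higher number from compound 1 to compound 2 (0.17 log units; within the scatter), was small. A step of similar size is therefore expected for compound 3, at most a modest rise and quite possibly none beyond the scatter; the expected step is a 1.3-fold higher number from compound 1 to compound 3 (0.10 log units; within the scatter). On that basis compound 3 is estimated to give 700 10^-6 cm/s in this assay, with an expected range from 450 10^-6 cm/s to 1050 10^-6 cm/s.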

Compound 3, apparent permeability: 787 10^-6 cm/s
Beside the measured number, compound 3's estimate is 1.1-fold (0.05 log units) below it; the range from low to high includes it.
By their numbers in this assay, from the lowest: compounds 1, 3 and 2 (each within the scatter of the next).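

In this assay the change at this second position, hydrogen in place of the methoxy that sits ortho to a methoxy group and meta to a large group, gives a 1.4-fold higher number from compound 1 to compound 3 (0.15 log units; within the scatter) and so stays inside the usual variation between repeat measurements. Read together with the earlier 1.5-fold higher number from compound 1 to compound 2 (0.17 log units; within the scatter) step, this shows that either methoxy of compound 1 can be replaced by hydrogen with no step beyond the scatter, so neither position stands out from the other in these data. No measurement at hand bears on the reason for this small size of step.

The compounds shown leave open whether a step beyond the scatter can be reached at this aromatic carbon at all, since hydrogen is the only replacement for methoxy seen here. An amine, a carboxylic acid or a longer alkoxy chain in that place would test this, and a ring carrying neither methoxy would show whether the two replacements taken together stay equally small.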